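Acylating the aniline nitrogen of a bile acid transporter inhibitor

The source may report more compounds than this note shows. Statements on the series, on what has been measured and on what is new or still open speak of the compounds shown alone.

Compound 3 `CCCC[C@]1(CC)CS(=O)(=O)c2ccc(N(C)C)cc2[C@@H](c2ccccc2)[C@H]1O` is the standout among the three measured compounds in an assay on cells for inhibition of ileal sodium/bile acid cotransporter (Homo sapiens); a lower number here means a stronger inhibitor, a higher number a weaker inhibitor: compound 3 gives 5 nM. Its parent, compound 1 `CCCC[C@]1(CC)CS(=O)(=O)c2ccc(N)cc2[C@@H](c2ccccc2)[C@H]1O`, carries a plain amino group and in this assay compound 1 gives 68 nM; the change from amino to dimethylamino gave a 14-fold lower number from compound 1 to compound 3 (1.13 log units; beyond the scatter). The hydroxy(tert-butoxycarbonyl)amino analogue, compound 2 `CCCC[C@]1(CC)CS(=O)(=O)c2ccc(N(O)C(=O)OC(C)(C)C)cc2[C@@H](c2ccccc2)[C@H]1O`, is the weakest, and in this assay compound 2 gives 2670 nM, a loss of a 39-fold higher number from compound 1 to compound 2 (1.59 log units; beyond the scatter) and a gap of a 530-fold lower number from compound 2 to compound 3 (2.73 log units; beyond the scatter).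

Compound 4 `CCCCCC(=O)Nc1ccc2c(c1)[C@@H](c1ccccc1)[C@@H](O)[C@](CC)(CCCC)CS2(=O)=O` changes the same position: (pentylcarbonyl)amino in place of dimethylamino on an aromatic carbon. Among the compounds with values here, two measured steps bear on this. Going from compound 3 back to the free amine already costs a 14-fold lower number from compound 1 to compound 3 (1.13 log units; beyond the scatter) in reverse, and placing a carbonyl-bearing substituent on that nitrogen, as in compound 2, cost a 39-fold higher number from compound 1 to compound 2 (1.59 log units; beyond the scatter). The (pentylcarbonyl)amino group of compound 4 shares the carbonyl on nitrogen with compound 2 but lacks the hydroxy and the tert-butoxy, so a smaller penalty than that of compound 2 seems likely, yet a clear loss against compound 3 is expected. Compound 4 is therefore estimated at 150 nM, between 20 nM and 1500 nM, a step of a 30-fold higher number from compound 3 to compound 4 (1.48 log units; beyond the scatter) expected to be beyond the scatter.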

Compound 4, half-maximal inhibitory concentration: 300 nM
For compound 4 the middle estimate is 2.0-fold (0.30 log units) below the measured one; the range from low to high includes it.
By their numbers in this assay, from the lowest: compound 3; then compound 1; then compound 4; then compound 2.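

In this assay, the (pentylcarbonyl)amino group shows that a carbonyl on this nitrogen raises the number even when the nitrogen keeps its hydrogen and carries no hydroxy or tert-butoxy group: acylating the free amino group gives a modest loss (a 4.4-fold higher number from compound 1 to compound 4 (0.64 log units; beyond the scatter)), while the change from dimethylamino gives a large one (a 60-fold higher number from compound 3 to compound 4 (1.78 log units; beyond the scatter)). The comparison with the hydroxy(tert-butoxycarbonyl)amino analogue adds that the carbonyl alone does not account for the full penalty seen there, since the number falls when the pentylcarbonyl group replaces that substituent (an 8.9-fold lower number from compound 2 to compound 4 (0.95 log units; beyond the scatter)). Nothing at hand bears on the cause of these steps. The compounds shown do not separate the effect of the carbonyl from that of the pentyl chain, which a shorter acetyl amide, a longer acyl chain or a simple pentylamino group could do. They also leave open whether the low number of compound 3 needs both methyl groups on the nitrogen, a question that methylamino and diethylamino analogues would address.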